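Benzyloxy to 4-chlorophenoxy: a step on thin evidence

The compounds below may be only part of what the source reports. "The series", "measured", "known", "first", "only" and "open" are said of these compounds alone.

In an ADME assay on L6 cells (Rattus norvegicus) for cytotoxicity, read by resazurin assay (a higher number here means a weaker inhibitor, a lower number a stronger inhibitor), compound 1 `CC(C)(C)c1ccc(-c2nc3ccc(-c4nc5cc(C(=N)N)ccc5[nH]4)cc3[nH]2)cc1` gives 13 ug/mL. Compound 2 `N=C(N)c1ccc2[nH]c(-c3ccc4nc(-c5ccc(OCc6ccccc6)cc5)[nH]c4c3)nc2c1` gives 17.4 ug/mL, which lies within the scatter of the value for compound 1. Going by the values given here, with only these two numbers available, compound 2 cannot be separated from its single neighbour.

Compound 3 `N=C(N)c1ccc2[nH]c(-c3ccc4nc(-c5ccc(Oc6ccc(Cl)cc6)cc5)[nH]c4c3)nc2c1` has 4-chlorophenyl in place of benzyl on an oxygen on an aromatic ring. The same difference can be read as benzyloxy to 4-chlorophenoxy.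

Among the compounds with values here, one measured step bears on this change, the swap of tert-butyl for benzyloxy on an aromatic carbon. That step, a 1.3-fold higher number from compound 1 to compound 2 (0.13 log units; within the scatter), stays within the scatter. Within the data shown here, it is a single comparison, and no measured compound carries the 4-chlorophenoxy group, so the support is weak. No step beyond the scatter is therefore expected in this assay, and no direction can be assigned with confidence. The expected change is a 1.2-fold lower number from compound 2 to compound 3 (0.09 log units; within the scatter), which is a working figure only. For compound 3 the estimate is 14 ug/mL, with an expected range of 6 ug/mL to 32 ug/mL.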

Compound 3, half-maximal inhibitory concentration: 46 ug/mL
Compound 3: middle estimate off by 3.3-fold (0.52 log units), on the low side, and the stated range ends below it.
By their numbers in this assay, from the lowest: compounds 1 and 2 (each within the scatter of the next); then compound 3.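

In this assay the group on an oxygen on an aromatic ring does move the number: 4-chlorophenyl in place of benzyl gives a 2.6-fold higher number from compound 2 to compound 3 (0.42 log units; beyond the scatter) and so leaves the scatter, although both groups have the same count of heavy atoms and each holds one six-membered aromatic ring of carbon only. Set against the tert-butyl of compound 1, the 4-chlorophenoxy group gives a 3.5-fold higher number from compound 1 to compound 3 (0.55 log units; beyond the scatter) as a second step beyond the scatter, whereas benzyloxy in place of tert-butyl stayed within it, so this end of the molecule is not silent in this assay and the size of the change depends on which group is placed there. No accompanying measurement offers an explanation for either step.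

The step from compound 2 to compound 3 removes the carbon link of the benzyl group and adds the chlorine in one change, and the two contributions cannot be separated from these compounds. A plain phenoxy group would divide that step, and a 4-fluorophenoxy or 4-methylphenoxy group would show whether the number follows chlorine itself or any group at that place on the ring.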